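Piperazine nitrogen substituent exchange in the diarylimidazole amide series

This account rests on a few compounds, and the source may have more. Where it says the series, first, only, none or still open, it means among the compounds named here.

Three compounds carry a shared core with a terminal amide, and the group beyond the amide carbonyl is where they differ. Compound 1 `Cn1c(-c2ccc(NC(=O)CSc3nc4ccccc4o3)cc2)nc(-c2ccccc2)c1-c1ccccc1` and compound 2 `Cn1c(-c2ccc(NC(=O)CSc3nc4ccccc4s3)cc2)nc(-c2ccccc2)c1-c1ccccc1` carry a heteroaryl thioether; compound 3 `CN(C)/C=C/N1CCN(CC(=O)Nc2ccc(-c3nc(-c4ccccc4)c(-c4ccccc4)n3C)cc2)CC1` carries a piperazine. In a functional assay on MCF7 cells (Homo sapiens) for cytotoxicity, read by MTT assay, with a stated time of 24 h (a higher number here means a weaker inhibitor, a lower number a stronger inhibitor), compound 1 gives 11.2 ug/mL and compound 2 gives 15.8 ug/mL, with a 1.4-fold higher number from compound 1 to compound 2 (0.15 log units; within the scatter). Compound 3 gives 80 ug/mL, the highest number of the three: a 7.1-fold higher number from compound 1 to compound 3 (0.85 log units; beyond the scatter) and a 5.1-fold higher number from compound 2 to compound 3 (0.70 log units; beyond the scatter).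

Compound 4 `COc1ccc(CN2CCN(CC(=O)Nc3ccc(-c4nc(-c5ccccc5)c(-c5ccccc5)n4C)cc3)CC2)cc1` is not yet measured. Against compound 3 the change is 4-methoxybenzyl in place of 2-(dimethylamino)ethenyl on an amine nitrogen in a ring. Among the compounds with values here, none of the measured steps bears on this position: the two steps beyond the scatter both exchange the whole thioether for the piperazine, and the one step at a fixed piperazine is absent from the measured set. The change leaves the piperazine and the rest of the core untouched, so the starting point is compound 3 with its 80 ug/mL, and no step beyond the scatter is expected in this assay in either direction.

Compound 4 is therefore estimated at 60 ug/mL, within 25 ug/mL to 150 ug/mL, which means an expected step of a 1.3-fold lower number from compound 3 to compound 4 (0.12 log units; within the scatter).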

Compound 4, half-maximal inhibitory concentration: 80 ug/mL
Compound 4: the middle estimate sits 1.3-fold (0.12 log units) below what was measured; low and high end bracket the measured number.
By their numbers in this assay, from the lowest: compounds 1 and 2 (each within the scatter of the next); then compounds 3 and 4 (each within the scatter of the next).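

In this assay, 4-methoxybenzyl in place of 2-(dimethylamino)ethenyl on the amine nitrogen of the piperazine gives no change at the digits printed from compound 3 to compound 4 (within the scatter), the first step read with the piperazine held fixed. The earlier steps shown here to compound 3 exchanged the whole thioether for the substituted piperazine, so they could not separate the piperazine from the group on its nitrogen. Here, a group of 9 heavy atoms with one six-membered aromatic ring of carbon only and a group of 5 heavy atoms with no ring and a double bond give the same printed number, so this pair shows no sensitivity to that exchange; no measurement on hand explains this result.

As far as these compounds go, whether this holds for other kinds of group on the same nitrogen remains open, for example a simple methyl, an acetyl, or a longer chain ending in a carboxylic acid or a primary amine. Also open, from the compounds shown here alone, is whether any group at this position can bring a piperazine compound close to the 11.2 ug/mL of compound 1.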